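The compounds below may be only part of what the source reports. "The series", "measured", "known", "first", "only" and "open" are said of these compounds alone.

Measured compounds:
Compound 1 `N=C(S)CCCCCn1nc(-c2ccccc2)ccc1=O`: 23.3 mg/kg in a functional assay on the whole organism (stomach) with Rattus norvegicus as the target; on this read-out lower numbers stand for an effect already at smaller amounts and higher numbers for an effect only at larger amounts of compound
Compound 2 `Cc1ccc(=O)n(CC(C)C(=N)S)n1`: > 100 mg/kg in this assay

Where compound 2 stands is known only as a limit: in this assay compound 2 gives > 100 mg/kg, which is a limit of the assay and not a number. Of the two values shown, one sits at the limit of > 100 mg/kg in this assay, at which 1 of the 2 values shown sits. Among the compounds with values here, compound 1, the other measured compound, gives 23.3 mg/kg in this assay; no step between these two compounds is counted here, so only the two values themselves can be compared.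

Compound 3 `CC(Cn1nc(-c2ccccc2)ccc1=O)C(=N)S` is not yet measured. It differs from compound 2 in one place: phenyl in place of methyl on an aromatic carbon. Within the data shown here, compound 1 also carries a phenyl on its core and gives 23.3 mg/kg in this assay, though its chain is longer, so no counted step links it to compound 3.

For compound 3 a step downward in this assay is expected, of the size an at least 2.5-fold lower number from compound 2 to compound 3 (0.39 log units; beyond the scatter), beyond the scatter. The estimate for compound 3 in this assay is 40 mg/kg, with a range from 15 mg/kg to 150 mg/kg.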

Compound 3, dose for half-maximal effect: 28.1 mg/kg
The estimate for compound 3 lay 1.4-fold (0.15 log units) above the measured number; measured number inside the range.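

On an aromatic carbon next to the ring nitrogen, phenyl in place of methyl gives a clear shift in this assay: an at least 3.5-fold lower number from compound 2 to compound 3 (0.55 log units; beyond the scatter). This is the first sign that the group at this place on the shared core matters, but the full size of the step stays unknown, since compound 2 gives only a limit and not a number: the limit of > 100 mg/kg in this assay, at which 1 of the 3 values shown sits.

With phenyl on the core, a group of 5 heavy atoms in place of a group of 7 heavy atoms on the chain gives a 1.2-fold higher number from compound 1 to compound 3 (0.08 log units; within the scatter), so these two chains cannot be told apart in this assay.

On these data alone, what remains open is whether phenyl itself is needed at this place, or whether a different group, such as ethyl, cyclohexyl or pyridyl, would give a similar number. As far as these compounds go, it is also open whether the two chains would still read alike with methyl on the core, and how a much longer chain or an amine at the end of the chain would fare.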